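Methoxy addition on the cinnamate aryl of compound 3

The compounds below may be only part of what the source reports. "The series", "measured", "known", "first", "only" and "open" are said of these compounds alone.

Measured compounds, a functional assay on HL-60 cells (Homo sapiens) for antiproliferative activity, read by MTT assay, with a stated time of 6 days; on this read-out higher numbers stand for weaker inhibition and lower numbers for stronger inhibition:
- compound 1 `CC(=O)O[C@@H]1C=CC(=O)O[C@@H]1[C@@H](COC(=O)c1ccc(Cl)cc1)OC(C)=O`: 32600 nM
- compound 2 `CC(=O)O[C@@H]1C=CC(=O)O[C@@H]1[C@@H](COC(=O)c1ccc([N+](=O)[O-])cc1)OC(C)=O`: 1110 nM
- compound 3 `O=C1C=C[C@@H](OCc2ccccc2)[C@@H]([C@@H](COC(=O)/C=C/c2ccccc2)OCc2ccccc2)O1`: 610 nM

Compound 3 carries the lowest number of the three in this assay. Its nearest neighbour is compound 2, whose value sits within the scatter of compound 3, so no order between those two is claimed. Compound 1 stands far away from compound 3, beyond the scatter.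

Compound 4 `COc1ccc(/C=C/C(=O)OC[C@@H](OCc2ccccc2)[C@H]2OC(=O)C=C[C@H]2OCc2ccccc2)cc1` differs from compound 3 in one place: methoxy in place of hydrogen on an aromatic carbon.

Going by the values given here, the only measured single-site step in the set is a 29-fold lower number from compound 1 to compound 2 (1.47 log units; beyond the scatter). That step concerns a different ring, the benzoate of the dibenzyl-free core, and a different pair of groups, so it bears on the present change only in showing that a substituent swap on an aromatic ring can move this assay by a large amount. Among the compounds with values here, no step in the data shows what methoxy in place of hydrogen does on the cinnamate aryl. With nothing closer to rest on, the expected step from compound 3 is a 1.0-fold lower number from compound 3 to compound 4 (0.01 log units; within the scatter), no direction favoured beyond the scatter.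

Compound 4 is therefore estimated at 600 nM, with a range from 200 nM to 2000 nM.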

Compound 4, half-maximal inhibitory concentration: 1570 nM
Compound 4: middle estimate off by 2.6-fold (0.42 log units), on the low side, and the stated range covers the measured number.
By their numbers in this assay, from the lowest: compounds 3, 2 and 4 (each within the scatter of the next, the first and the last beyond it); then compound 1.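

Working note on the cinnamate aryl: in this assay the first single-site reading here is a 2.6-fold higher number from compound 3 to compound 4 (0.41 log units; beyond the scatter), so methoxy in place of hydrogen, para to a large group, is not neutral at this position, and the change moves the series modestly towards weaker inhibition. Going by these compounds alone, this step is much smaller than a 29-fold lower number from compound 1 to compound 2 (1.47 log units; beyond the scatter), which belongs to a different aromatic ring and a different pair of groups, so the two show only that substituent swaps on aromatic rings can differ widely in size. No measurement available speaks to the origin of the new step.

Still open, as far as these compounds go, is whether the rise in the number is specific to methoxy or would also follow from other groups at the same place on this aryl, such as a hydroxyl, a fluorine, an amine or a longer ethoxy chain. Also open, from the compounds shown here alone, is whether nitro on the cinnamate aryl would give a step like the one seen on the benzoate, and whether methoxy would give the same step elsewhere on this ring.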